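The source may report more compounds than this note shows. Statements on the series, on what has been measured and on what is new or still open speak of the compounds shown alone.

Of the compounds shown here, three have been measured in an assay on isolated protein for binding affinity to Adrenergic receptor alpha-1 (Rattus norvegicus), read by radioligand binding; on this read-out lower numbers stand for stronger inhibition and higher numbers for weaker inhibition. Compound 1 `c1ccc2c(c1)CCCC2CCCCN1CCCCC1` gives 4.7 nM. Compound 2 `C1=C(CCCCN2CCCCC2)c2ccccc2CC1` gives 3.9 nM, and compound 3 `CCCN(CCC)CCCCC1=CCCc2ccccc21` gives 3.9 nM. The difference between the core of compound 1 and the core of compound 2 is not broken down here; the two values lie within the scatter of each other. Compound 1 holds the highest of the three numbers, but its gaps to compound 2 and to compound 3 are both within the scatter, so no order among the three is read from them.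

One structural change occurs twice among the compounds shown. From compound 2 to compound 3 it is dipropylamino in place of piperidin-1-yl on a saturated chain carbon, four bonds along the chain from a double-bonded ring carbon, and it made no change at the digits printed from compound 2 to compound 3 (within the scatter). From compound 1 to compound 4 `CCCN(CCC)CCCCC1CCCc2ccccc21`, not yet measured, it is dipropylamino in place of piperidin-1-yl on a saturated chain carbon, four bonds along the chain from a saturated ring carbon. The surroundings of the place differ: in compound 2 the chain carbon bearing the amine sits four bonds along the chain from a double-bonded ring carbon, in compound 1 four bonds along the chain from a saturated ring carbon, so the two are the same kind of change, not the same change.

Because the step of no change at the digits printed from compound 2 to compound 3 (within the scatter) stayed within the scatter, the corresponding step from compound 1 to compound 4 is expected to be small as well, estimated at a 1.1-fold higher number from compound 1 to compound 4 (0.03 log units; within the scatter). This rests on compound 1 starting at 4.7 nM and on nothing in the measured steps pointing away from it. In this assay compound 4 is expected to come in at 5 nM, with a range from 2.5 nM to 10 nM.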

Compound 4, inhibition constant: 4.7 nM
For compound 4 the middle estimate is 1.1-fold (0.03 log units) above the measured one; low and high end bracket the measured number.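

Dipropylamino in place of piperidin-1-yl, on a saturated chain carbon, four bonds along the chain from a saturated ring carbon, gives in this assay no change at the digits printed from compound 1 to compound 4 (within the scatter). Set beside the earlier step on the other core, the same kind of change carries over with no gap beyond the scatter: the same change on two cores in this assay, no change at the digits printed (within the scatter) from compound 2 to compound 3 and no change at the digits printed (within the scatter) from compound 1 to compound 4, 1.0-fold (0.00 log units) apart, within the scatter of two such steps

On these two cores, then, piperidin-1-yl and dipropylamino cannot be told apart in this assay, but this rests on two pairs only, and both steps lie within the scatter, so it does not show that the change would carry to a further core, nor that a step of real size would transfer between cores.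

The compounds shown leave open whether the numbers hold with other groups on the chain, such as morpholin-4-yl, a primary amine or a carboxylic acid, since piperidin-1-yl and dipropylamino are the only two amines seen in this place. They also leave open how a longer chain would read in this assay, and whether the two amines stay equal on a core carrying a substituent on the benzene ring, for instance a methoxy group.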